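The source may hold more compounds than are shown below. What is called first, only, known or untested is meant among the compounds shown, and "the series" means these compounds.

In a functional assay on the whole organism (strain Wistar) for inhibition, with Rattus norvegicus as the target, read by paw edema, with a stated time of 4 h, at a dose of 10 mg/kg by the oral route (on this read-out lower numbers stand for less inhibition and higher numbers for more inhibition at the one dose given (going by the name of the read-out)), the three measured compounds give these numbers:

compound 1 `CC(C)Cc1ccc(C(C)c2nnc(COc3ccc(-c4ccccc4)cc3)o2)cc1`: 79.5%
compound 2 `Fc1ccc(Nc2nnc(COc3ccc(-c4ccccc4)cc3)o2)cc1`: 52.3%
compound 3 `Brc1ccc(Nc2nnc(COc3ccc(-c4ccccc4)cc3)s2)cc1`: 63.6%

Compound 3 stands second highest of the three, beyond the usual scatter from both neighbours: compound 2 lies lower and compound 1 lies higher. Compound 4 `Cc1ccc(Nc2nnc(COc3ccc(-c4ccccc4)cc3)s2)c(C)c1` has not yet been measured. It differs from compound 3 in one place: 2,4-dimethylphenyl in place of 4-bromophenyl on a nitrogen on an aromatic ring. Within the data shown here, no pair of measured compounds shows this kind of swap, so the size of the step is open; an aryl-for-aryl exchange without change in donors or acceptors is expected to move the number only a little, in no clear direction. The expected step from compound 3 to compound 4 is a number 3.6 percentage points lower from compound 3 to compound 4 (within the scatter). Compound 4 is therefore estimated at 60%, in the range 45% to 75%.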

Compound 4, a percentage reported as inhibition, in the whole organism at one dose (the size of the read-out at that dose, not a potency): 56.8%
Compound 4: middle estimate off by 3.2 percentage points, on the high side, and the stated range covers the measured number.
By their numbers in this assay, from the lowest: compounds 2, 4 and 3 (each within the scatter of the next, the first and the last beyond it); then compound 1.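

In this assay, putting 2,4-dimethylphenyl in place of 4-bromophenyl on a nitrogen on an aromatic ring gives a number 6.8 percentage points lower from compound 3 to compound 4 (within the scatter), the first step read at this position. At this position, then, a phenyl ring with a bromine and one with two methyl groups cannot be told apart at this single dose. No measurement shown here speaks to why this is so. Still open, on these data alone, is whether a plain phenyl or a non-aromatic group such as morpholine on this nitrogen would keep the number. As far as these compounds go, a carboxylic acid on the phenyl ring is equally open.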